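This account rests on a few compounds, and the source may have more. Where it says the series, first, only, none or still open, it means among the compounds named here.

Measured so far in a functional assay on cells (leukaemia cell line, Homo sapiens) for inhibition, read by sulforhodamine B assay, with a stated time of 48 h; on this read-out higher numbers stand for weaker inhibition of growth and lower numbers for stronger inhibition of growth:
compound 1, `O=S(=O)(Nc1ccc(Cl)c(Cl)c1)c1ccc(-c2cnc(C3CC3)o2)cc1` — 416 nM
compound 2, `O=S(=O)(Nc1ccc(Cl)c(F)c1)c1ccc(-c2cnc(C3CC3)o2)cc1` — 380 nM

Compound 1 gives the higher of the two numbers, but compound 2 sits so close that the two cannot be told apart: the change from compound 1 to compound 2 is a 1.1-fold lower number from compound 1 to compound 2 (0.04 log units; within the scatter), a swap of fluoro for chloro on an aromatic carbon that left growth inhibition essentially unchanged.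

Compound 3, `O=S(=O)(Nc1cc(F)cc(Cl)c1)c1ccc(-c2cnc(C3CC3)o2)cc1`, has not yet been measured. It differs from compound 1 in one place: 3-chloro-5-fluorophenyl in place of 3,4-dichlorophenyl on a sulfonamide nitrogen. Among the measured compounds shown here, the only measured step that bears on this is the one from compound 1 to compound 2, and it was within the scatter. Compound 3 again keeps one chloro and exchanges the other for a fluoro, now on a different arrangement of the same ring, so no step beyond the scatter is expected in this assay in either direction.

Compound 3 is therefore estimated at 450 nM, with a range from 200 nM to 1000 nM. The expected step is a 1.1-fold higher number from compound 1 to compound 3 (0.03 log units; within the scatter).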

Compound 3, concentration for 50% growth inhibition: 1440 nM
Compound 3: middle estimate off by 3.2-fold (0.51 log units), on the low side; measured number outside the range, above it.
By their numbers in this assay, from the lowest: compounds 2 and 1 (each within the scatter of the next); then compound 3.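

In this assay, putting 3-chloro-5-fluorophenyl in place of 3,4-dichlorophenyl on the sulfonamide nitrogen gives a 3.5-fold higher number from compound 1 to compound 3 (0.54 log units; beyond the scatter), and putting it in place of 4-chloro-3-fluorophenyl gives a 3.8-fold higher number from compound 2 to compound 3 (0.58 log units; beyond the scatter), so growth inhibition is weaker in both cases. The second change is the more telling one, since compound 2 and compound 3 carry the same two halogens, one chloro and one fluoro, and differ only in how these are arranged on the ring; this position therefore responds to the arrangement of the halogens, although the earlier swap of one halogen for another showed no effect beyond the scatter. Nothing measured here accounts for this difference.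

The compounds shown leave open which part of the rearrangement carries the loss, as a ring such as 3,5-dichlorophenyl would help to separate. They also leave open how a methoxy group or an amine would fare on this ring in place of a halogen.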